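Notes on the substituent at the amide-type nitrogen

A few compounds are considered here, and "the series" means these few. Any claim that something is new, unique, unknown or untested is made for them only; others in the source may bear on it.

compound 1 `O=C1Nc2ccc(-c3ccc(C(F)(F)F)cc3)cc2C1=O`: > 10000 nM
compound 2 `COc1ccc(-c2ccc3c(c2)C(=O)C(=O)N3C)cc1`: 4980 nM

In a functional assay on K562 cells (Homo sapiens) for antiproliferative activity, read by MTT assay, with a stated time of 48 h (on this read-out lower numbers stand for stronger inhibition and higher numbers for weaker inhibition), compound 1 gives only a limit, > 10000 nM. In this assay, going by the values given here, compound 2 gives 4980 nM, the only number in the set. Compound 1 sits at the limit of > 10000 nM in this assay, at which 1 of the 2 values shown sits. Compound 3 `COc1ccc(-c2ccc3c(c2)C(=O)C(=O)N3Cc2ccc(F)cc2)cc1` carries 4-fluorophenyl in place of hydrogen on a saturated chain carbon bound to an amide-type nitrogen in a ring. Among the compounds with values here, no measured pair covers such a change, so its size and direction rest on no data from these compounds. The step expected is a 2.5-fold lower number from compound 2 to compound 3 (0.40 log units; beyond the scatter), a modest gain with wide uncertainty. Compound 3 is estimated at 2000 nM, within a range from 400 nM to 9000 nM.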

Compound 3, half-maximal inhibitory concentration: 560 nM
Compound 3: the middle estimate sits 3.6-fold (0.55 log units) above what was measured; measured number inside the range.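

Replacing methyl with 4-fluorobenzyl on the amide-type nitrogen in the ring gives an 8.9-fold lower number from compound 2 to compound 3 (0.95 log units; beyond the scatter) in this assay. Going by these compounds alone, this is the first step read at this position: it shows that the number responds to this change and that a group carrying a six-membered aromatic ring is tolerated here. Nothing shown bears on why the step arises.

Open, going by these compounds, is whether the step depends on the fluorine or on the ring itself. Plain benzyl would separate the two, while a longer chain ending in an amine would test how far the position extends.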